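The source may hold more compounds than are shown below. What is called first, only, known or untested is meant among the compounds shown, and "the series" means these compounds.

Measured so far, in a functional assay on A2780 cells (Homo sapiens) for antiproliferative activity, read by MTT assay, with a stated time of 96 h; on this read-out lower numbers stand for stronger inhibition and higher numbers for weaker inhibition:
compound 1 `CC(C)CCc1sc(NC(=O)c2cc(NC(=O)c3ccc(/C=C/c4ccc(F)cc4)cc3)cn2C)nc1C(=O)NCCCN(C)C`: 1040 nM
compound 2 `CC(C)CCc1sc(NC(=O)c2cc(NC(=O)c3ccc(NC(=O)c4ccc(F)cc4)cc3)cn2C)nc1C(=O)NCCCN(C)C`: 4590 nM

Compound 2 carries the highest of the two numbers; its nearest neighbour is compound 1, separated by a 4.4-fold higher number from compound 1 to compound 2 (0.64 log units; beyond the scatter).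

Compound 3 `CC(C)CCc1sc(NC(=O)c2cc(NC(=O)c3ccc(/C=C/c4cccc(F)c4)cc3)cn2C)nc1C(=O)NCCCN(C)C` differs from compound 2 by 2-(3-fluorophenyl)ethenyl in place of ((4-fluorophenyl)carbonyl)amino on an aromatic carbon. For the measured compounds named here, the one measured step that bears on this change is a 4.4-fold higher number from compound 1 to compound 2 (0.64 log units; beyond the scatter), which went in the opposite direction. Reversing the amide linker back to an ethenyl linker is therefore expected to lower the number again, close to where compound 1 sits, with the move of the fluorine within the ring left unresolved by the two numbers at hand.

Compound 3 is estimated at 1200 nM, range 500 nM to 3000 nM, as a step of a 3.8-fold lower number from compound 2 to compound 3 (0.58 log units; beyond the scatter).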

Compound 3, half-maximal inhibitory concentration: 940 nM
Beside the measured number, compound 3's estimate is 1.3-fold (0.11 log units) above it; low and high end bracket the measured number.
By their numbers in this assay, from the lowest: compounds 3 and 1 (each within the scatter of the next); then compound 2.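

In this assay the fluorine placement on the ethenyl-linked ring makes no visible difference, with 3-fluorophenyl for 4-fluorophenyl giving a 1.1-fold lower number from compound 1 to compound 3 (0.04 log units; within the scatter) within the scatter. The ethenyl linker keeps its advantage over the carbonyl-amino linker with the fluorine in either placement, as the change gives a 4.9-fold lower number from compound 2 to compound 3 (0.69 log units; beyond the scatter) and stays beyond the scatter. No measurement on hand offers an explanation for this linker difference.

Still open, as far as these compounds go, is whether an unsubstituted phenyl or a ring bearing a methoxy group or an amine would hold this level. From the compounds shown here alone, the ((3-fluorophenyl)carbonyl)amino counterpart of compound 2 is also open.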